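A few compounds are considered here, and "the series" means these few. Any claim that something is new, unique, unknown or untested is made for them only; others in the source may bear on it.

Measured compounds in a functional assay on PC-3 cells (Homo sapiens) for cytotoxicity, read by sulforhodamine B assay; on this read-out lower numbers stand for stronger inhibition of growth and higher numbers for weaker inhibition of growth:

compound 1, `COc1cccc(OC)c1OCCNCCOc1ccccc1OCc1ccccc1`, gives 26900 nM
compound 2, `COc1cccc(OC)c1OCCNCCOc1ccccc1OCc1cccc(C)c1`, gives 12000 nM
compound 3, `COc1cccc(OC)c1OCCNCCOc1ccccc1OCc1ccccc1[N+](=O)[O-]`, gives 13200 nM

Among these three numbers compound 3 stands second highest. Its nearest neighbour is compound 2: the change a 1.1-fold higher number from compound 2 to compound 3 (0.04 log units; within the scatter) lies within the scatter, so the two cannot be told apart. The furthest is compound 1: the change a 2.0-fold lower number from compound 1 to compound 3 (0.31 log units; beyond the scatter) goes beyond the scatter, a modest gain on adding the nitro.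

Compound 4, `COc1ccccc1COc1ccccc1OCCNCCOc1c(OC)cccc1OC`, differs from compound 3 in one place: methoxy in place of nitro on an aromatic carbon. The new group sits on an aromatic carbon of a six-membered aromatic ring of carbon only, ortho to a large group.

Going by the values given here, two measured steps bear on this. Adding a nitro to that ring, a 2.0-fold lower number from compound 1 to compound 3 (0.31 log units; beyond the scatter), and adding a methyl to it, a 2.2-fold lower number from compound 1 to compound 2 (0.35 log units; beyond the scatter), each lowered the number modestly. Among the compounds with values here, no measured compound carries a methoxy at this place, so the data do not settle whether a methoxy keeps that gain. Swapping the nitro for a methoxy is therefore expected to give at most a small shift, a 1.2-fold higher number from compound 3 to compound 4 (0.08 log units; within the scatter), probably within the scatter. Compound 4 is estimated at 16000 nM in this assay, within a range of 7000 nM to 40000 nM.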

Compound 4, concentration for 50% growth inhibition: 8900 nM
For compound 4 the middle estimate is 1.8-fold (0.25 log units) above the measured one; measured number inside the range.
By their numbers in this assay, from the lowest: compounds 4, 2 and 3 (each within the scatter of the next); then compound 1.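

In this assay, a methoxy on this aromatic carbon, ortho to a large group, keeps the gain over plain hydrogen: a 3.0-fold lower number from compound 1 to compound 4 (0.48 log units; beyond the scatter), a modest step, but one that clears the scatter, as the steps for the nitro and the methyl did. Exchanging the nitro for the methoxy gives a 1.5-fold lower number from compound 3 to compound 4 (0.17 log units; within the scatter), and 2-methoxyphenyl in place of 3-methylphenyl gives a 1.3-fold lower number from compound 2 to compound 4 (0.13 log units; within the scatter), so compound 2, compound 3 and compound 4 cannot be told apart in this assay. The swap from nitro to methoxy changes the group's atoms and its count of hydrogen-bond acceptors with no readable effect on the number, and nothing available explains why these substituted compounds fall so close together.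

The compounds shown leave open whether an amine, a carboxylic acid or a longer chain such as an ethoxy at this place would keep the same modest gain, lose it or go further. They also leave open whether a methoxy and a methyl together on this ring would add their steps or give no more than either group alone.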